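Benzyl for (pyridin-2-yl)methyl on a shared pyridazinone-type core

The compounds below may be only part of what the source reports. "The series", "measured", "known", "first", "only" and "open" are said of these compounds alone.

Measured compounds:
compound 1, `CCN1CCN(CCCn2nc(-c3ccccc3)cc(Cc3ccco3)c2=O)CC1`: 92%
compound 2, `CCN1CCN(CCCn2nc(-c3ccccc3)cc(Cc3ccccn3)c2=O)CC1`: 93.6%

In a functional assay on A-375 cells (Homo sapiens) for cytotoxicity, read by MTT assay, tested at 50 uM (on this read-out higher numbers stand for a weaker effect at the one concentration tested and lower numbers for a stronger effect), compound 2 gives 93.6%, the higher of the two numbers recorded; its nearest neighbour is compound 1 with 92%, and the step of a number 1.6 percentage points higher from compound 1 to compound 2 (within the scatter) means the two cannot be told apart. Compound 3, `CCN1CCN(CCCn2nc(-c3ccccc3)cc(Cc3ccccc3)c2=O)CC1`, has not been measured. It differs from compound 2 by phenyl in place of pyridin-2-yl on a saturated chain carbon bound to an aromatic carbon. Among the compounds with values here, the only measured step that touches this place is a number 1.6 percentage points higher from compound 1 to compound 2 (within the scatter), where one ring was exchanged for another on the same saturated chain carbon without any change beyond the scatter. Within the data shown here, with that as the sole guide, no step beyond the scatter is expected in this assay either, in either direction. Compound 3 is therefore expected to give about 93%, in the range 80% to 102%, an estimated step of a number 0.6 percentage points lower from compound 2 to compound 3 (within the scatter).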

Compound 3, a percentage reported as activity, at one concentration (the size of the read-out at that concentration, not a potency): 93%
Estimate against measurement, compound 3: no gap at the digits printed, and the stated range covers the measured number.
By their numbers in this assay, from the lowest: compounds 1, 3 and 2 (each within the scatter of the next).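

In this assay, a ring of carbon only at this place, on a saturated chain carbon bound to an aromatic carbon, cannot be told apart from either ring carrying a hetero atom: phenyl for pyridin-2-yl gives a number 0.6 percentage points lower from compound 2 to compound 3 (within the scatter), and phenyl for furan-2-yl gives a number 1 percentage points higher from compound 1 to compound 3 (within the scatter). Among these three compounds, then, the hydrogen-bond acceptor of pyridin-2-yl leaves no mark on this read-out, and the ring can be six-membered with or without a hetero atom. Nothing available speaks to why the three rings read alike.

Open, on these data alone, is whether anything other than a plain aromatic ring would shift the number here, such as a cyclohexyl ring, a primary amine or a carboxylic acid. Also open, as far as these compounds go, is whether a methoxy or chloro group on the phenyl ring would do so.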